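Chloro in place of hydrogen: compound 1 to compound 3

The source may hold more compounds than are shown below. What is called first, only, known or untested is meant among the compounds shown, and "the series" means these compounds.

Compound 1 `CCn1cc(-c2nc3ccccc3[nH]2)c(=O)c2cc(F)c(N3CCNCC3)cc21` is the reference point of this pair. In a functional assay on HT-29 cells (Homo sapiens) for cytotoxicity, read by sulforhodamine B assay, with a stated time of 48 h (a higher number here means a weaker inhibitor of growth, a lower number a stronger inhibitor of growth), compound 1 gives only a limit, > 10000 nM. Compound 2 `CCn1cc(-c2nc3ccccc3[nH]2)c(=O)c2cc(F)c(N3CCNCC3)nc21` is the other measured member. In this assay compound 2 likewise returns a limit, > 10000 nM. Compound 1 therefore stands at the limit of > 10000 nM in this assay, at which 2 of the 2 values shown sit, so no number places it relative to compound 2. Compound 3 `CCn1cc(-c2nc3ccc(Cl)cc3[nH]2)c(=O)c2cc(F)c(N3CCNCC3)cc21` differs from compound 1 in one place: chloro in place of hydrogen on an aromatic carbon. For the measured compounds named here, no measured step of this kind exists in the set, so no step beyond the scatter is expected in this assay in either direction. The expected step is a step that the limit leaves unreadable from compound 1 to compound 3. Compound 3 is estimated at 15000 nM, between 5000 nM and 50000 nM.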

Compound 3, concentration for 50% growth inhibition: 1800 nM
Compound 3: the middle estimate sits 8.3-fold (0.92 log units) above what was measured; the whole stated range lies above it.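

In this assay, for the compounds shown here, the 6-chloro-1H-benzimidazol-2-yl group of compound 3 gives the only value shown that is a number and not a limit, 1800 nM. Chloro in place of hydrogen on this aromatic carbon brings an at least 5.5-fold lower number from compound 1 to compound 3 (0.74 log units; beyond the scatter), so a change at this position alone is enough to bring a measurable value. Compound 1 carries only a limit, so the step has a floor but no measured size. Still open, on these data alone, is whether bromo, methyl or methoxy on the same carbon gives a comparable step, and whether chloro does so on the core of compound 2.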